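The source may hold more compounds than are shown below. What is called first, only, known or untested is meant among the compounds shown, and "the series" means these compounds.

Compounds measured so far:
compound 1 `O=C(COc1ccncc1-c1ccc2ccccc2c1)N1CCOCC1` — "not determined" (no result reported)
compound 2 `O=C(O)COc1ccncc1-c1ccc2ccccc2c1` — "not determined" (no result reported)
compound 3 `CCOC(=O)/C=C/c1ccncc1-c1ccc2cc[nH]c2c1` — 12.1 nM

Compound 2 stands without a number: in an assay on a protein complex for inhibition of CDK8/Cyclin C (Homo sapiens), with a stated time of 1 h (a higher number here means a weaker inhibitor, a lower number a stronger inhibitor), no result is reported for it, and the same holds for compound 1. Among the compounds with values here, only compound 3 carries a measured value, 12.1 nM in this assay, and its structure departs from compound 2 in more than one place, so it offers no direct step. Compound 4 `CNC(=O)CCc1ccncc1-c1ccc2ccccc2c1` differs from compound 2 by 2-(methylcarbamoyl)ethyl in place of carboxymethoxy on an aromatic carbon. Within the data shown here, with no measured step from compound 2 to any neighbour, neither size nor direction of the change can be read from the data; the expectation rests on compound 3 alone, which anchors this series in the low range of this assay. Compound 4 is therefore estimated at 150 nM, within 20 nM to 1500 nM.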

Compound 4, half-maximal inhibitory concentration: 21.1 nM
The estimate for compound 4 lay 7.1-fold (0.85 log units) above the measured number, and the stated range covers the measured number.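

Within the data shown here, compound 2 carries no number, so no step to compound 4 can be read. The compounds shown leave open what replacing carboxymethoxy with 2-(methylcarbamoyl)ethyl alone does to inhibition. No supporting data bear on the value of compound 4.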